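The source may report more compounds than this note shows. Statements on the series, on what has been measured and on what is new or still open speak of the compounds shown alone.

Measured compounds:

- compound 1 `CCCCCCOC(=O)Nc1ccc([Se]C#N)cc1` gives 72700 nM in a functional assay on CCRF-CEM cells (Homo sapiens) for cytotoxicity, read by MTT assay, with a stated time of 72 h; on this read-out lower numbers stand for higher toxicity in this test and higher numbers for lower toxicity in this test
- compound 2 `N#C[Se]c1ccc(NC(=O)Oc2ccc(F)cc2)cc1` gives 71100 nM in this assay

Both compounds carry the same selenocyanate-bearing core and differ only in the carbamate part. On the two numbers at hand compound 2 stands level with compound 1: the gap between them is within the usual scatter of this kind of measurement, so the two cannot be told apart in this assay.

Compound 3 `N#C[Se]c1ccc(NC(=O)Oc2ccc(Cl)cc2)cc1` is the next compound and has not yet been measured. It differs from compound 2 in one place: chloro in place of fluoro on an aromatic carbon. Going by the values given here, no measured pair in this set shows what such a swap does here, so there is nothing to lean on beyond the two numbers above. Given that compound 1 and compound 2 sit so close together despite a larger change in the carbamate part, the expected step from compound 2 to compound 3 in this assay is small, with no clear direction, and expected to stay within the scatter: a 1.1-fold lower number from compound 2 to compound 3 (0.04 log units; within the scatter). Compound 3 is therefore expected to give about 65000 nM, within a range from 30000 nM to 140000 nM.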

Compound 3, concentration lethal to 50% of the cells: 71800 nM
Compound 3: middle estimate off by 1.1-fold (0.04 log units), on the low side, within the range that was stated.
By their numbers in this assay, from the lowest: compounds 2, 3 and 1 (each within the scatter of the next).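

In this assay, chloro in place of fluoro on an aromatic carbon, para to a large group, comes to a 1.0-fold higher number from compound 2 to compound 3 (0.00 log units; within the scatter). Going by these compounds alone, this is the first measured step at this position, and it shows that in this test fluoro and chloro cannot be told apart there, so either group can stand at that place without a step that rises above the ordinary spread of repeated measurements. No measurement shown here offers any explanation of why compound 2 and compound 3 read alike.

Going by these compounds, what remains open is whether this position is as undemanding for groups other than these two, since an amine, a carboxylic acid or a longer chain on the same aromatic carbon could read alike or quite differently. A single step also says nothing about the same swap on another aromatic carbon of the ring, so no general rule about this change can be drawn from compound 2 and compound 3 alone.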